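The compounds below may be only part of what the source reports. "The series", "measured", "known", "first", "only" and "open" are said of these compounds alone.

Among the compounds with values here, compound 2, `CO[C@H]1C[C@H](Oc2cc(F)c(F)c(-c3cc(F)c(OCCCCC(=O)O)c(F)c3)c2)C1`, gives 68800 nM in a functional assay on CHO cells for agonist activity at Free fatty acid receptor 1 (Homo sapiens), read by calcium flux (a higher number here means that more compound is needed for the effect, a lower number that less compound is needed), the only plain number in the set. Compound 1, `CO[C@H]1C[C@H](Oc2cc(F)c(F)c(-c3cc(F)c(SCCCC(=O)O)c(F)c3)c2)C1`, reached only a limit of this assay, > 100000 nM. Within the data shown here, the one measured step, an at least 1.4-fold lower number from compound 1 to compound 2 (0.16 log units; that floor lies within the scatter), is held back by that limit, (the limit of > 100000 nM in this assay, at which 1 of the 2 values shown sits), so it cannot say how large the gain really was. Compound 3, `CO[C@H]1C[C@H](Oc2cc(F)c(F)c(-c3cc(F)c(OCCCCCC(=O)O)c(F)c3)c2)C1`, differs from compound 2 by carboxymethyl in place of carboxy on a saturated chain carbon, four bonds along the chain from an oxygen on an aromatic ring. Among the measured compounds shown here, no measured step extends the chain in this way, so no step beyond the scatter is expected, a 1.1-fold lower number from compound 2 to compound 3 (0.06 log units; within the scatter). Compound 3 is therefore estimated at 60000 nM, between 15000 nM and 200000 nM.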

Compound 3, half-maximal effective concentration: 11000 nM
Compound 3: middle estimate off by 5.5-fold (0.74 log units), on the high side, outside the stated range (below it).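

Chain length at this position clearly matters in this assay: carboxymethyl in place of carboxy gives a 6.3-fold lower number from compound 2 to compound 3 (0.80 log units; beyond the scatter). Within the data shown here, this is the first step here measured between two plain numbers, so its size can be read directly. The wider step, an at least 9.0-fold lower number from compound 1 to compound 3 (0.95 log units; beyond the scatter), gives only a floor: the limit of > 100000 nM in this assay, at which 1 of the 3 values shown sits.

Going by these compounds, whether a still longer chain would lower the number further, or where the gain would stop, remains open. So does whether an amide at the chain end could replace the carboxylic acid.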